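Swapping the piperidine substituent in a TRPV1 antagonist series

A few compounds are considered here, and "the series" means these few. Any claim that something is new, unique, unknown or untested is made for them only; others in the source may bear on it.

Measured compounds:
compound 1 `CC(C(=O)NCc1ccc(C(F)(F)F)nc1N(C)C)c1ccc(NS(C)(=O)=O)c(F)c1`: 19.1 nM
compound 2 `CC1CCCN1c1nc(C(F)(F)F)ccc1CNC(=O)[C@@H](C)c1ccc(NS(C)(=O)=O)c(F)c1`: 0.3 nM
compound 3 `CC(C(=O)NCc1ccc(C(F)(F)F)nc1N1CCC(C)(C)CC1)c1ccc(NS(C)(=O)=O)c(F)c1`: 0.3 nM

In a functional assay on CHO-K1 cells for antagonist activity at transient receptor potential cation channel subfamily V member 1 (Homo sapiens), read by FLIPR (a lower number here means a stronger inhibitor, a higher number a weaker inhibitor), compound 3 stands level with compound 2 and the two share the lowest number, while compound 1 sits far higher, a gap of a 64-fold lower number from compound 1 to compound 3 (1.80 log units; beyond the scatter). Compound 4 `CC(C(=O)NCc1ccc(C(F)(F)F)nc1N1CCC(CN(C)C)CC1)c1ccc(NS(C)(=O)=O)c(F)c1` carries the change (4-((dimethylamino)methyl)piperidin-1-yl in place of 4,4-dimethylpiperidin-1-yl on an aromatic carbon). Going by the values given here, only the step from compound 1 to compound 3 bears on it, and that step changed a small group for a ring, whereas here the ring stays and its substituent alone is exchanged. A step of modest size toward a higher number is therefore expected, a 3.3-fold higher number from compound 3 to compound 4 (0.52 log units; beyond the scatter). Compound 4 is estimated at 1 nM, between 0.2 nM and 6 nM.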

Compound 4, inhibition constant: 2.1 nM
For compound 4 the middle estimate is 2.1-fold (0.32 log units) below the measured one; the range from low to high includes it.
By their numbers in this assay, from the lowest: compounds 2 and 3 (each within the scatter of the next); then compound 4; then compound 1.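

In this assay the substituent on the piperidine ring matters, not just the presence of the ring: 4-((dimethylamino)methyl)piperidin-1-yl in place of 4,4-dimethylpiperidin-1-yl gives a 7.0-fold higher number from compound 3 to compound 4 (0.85 log units; beyond the scatter). Even so, this ring with its amine side chain keeps much of the gain over the open dimethylamino group, with a 9.1-fold lower number from compound 1 to compound 4 (0.96 log units; beyond the scatter). Nothing measured here accounts for either step.

Going by these compounds, it remains open how a hydroxyl group or a carboxylic acid on the piperidine ring would compare. A morpholine ring in its place is equally untested among the compounds shown.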